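The source may hold more compounds than are shown below. What is called first, only, known or untested is meant among the compounds shown, and "the series" means these compounds.

Working notes on the series. Compound 1 `N#Cc1ccc(NC(=O)CN2C(=O)/C(=C/c3ccc(-c4ccc(Cl)cc4)o3)SC2=S)cc1` is the reference point. For the measured compounds named here, in a functional assay on REH cells (Homo sapiens) for cytotoxicity, read by MTT assay, with a stated time of 72 h (on this read-out lower numbers stand for stronger inhibition and higher numbers for weaker inhibition), compound 1 gives 90000 nM, which is the highest of the two numbers so far, with compound 2 as its nearest neighbour within the scatter. Compound 2 `O=C(CN1C(=O)/C(=C/c2ccc(-c3ccc(Cl)cc3)o2)SC1=S)NCc1ccccc1Cl` gives 70000 nM in this assay; the step of a 1.3-fold lower number from compound 1 to compound 2 (0.11 log units; within the scatter) carries the 2-chlorobenzyl in place of 4-cyanophenyl on an amide-type nitrogen.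

Compound 3 `Cc1cccc(CNC(=O)CN2C(=O)/C(=C/c3ccc(-c4ccc(Cl)cc4)o3)SC2=S)c1` is not yet measured. It differs from compound 1 by 3-methylbenzyl in place of 4-cyanophenyl on an amide-type nitrogen. Going by the values given here, the one measured step that bears on this is the one from compound 1 to compound 2, where the same 4-cyanophenyl on the amide-type nitrogen was exchanged for a benzyl-type group and the number moved by a 1.3-fold lower number from compound 1 to compound 2 (0.11 log units; within the scatter), within the scatter. On that basis no step beyond the scatter is expected in this assay for the exchange to 3-methylbenzyl; the expected step is a 1.2-fold lower number from compound 1 to compound 3 (0.08 log units; within the scatter). Compound 3 is therefore estimated at 75000 nM, with a range from 30000 nM to 180000 nM.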

Compound 3, half-maximal inhibitory concentration: 53000 nM
The estimate for compound 3 lay 1.4-fold (0.15 log units) above the measured number; measured number inside the range.
By their numbers in this assay, from the lowest: compounds 3, 2 and 1 (each within the scatter of the next).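

In this assay, a second benzyl-type group on the amide-type nitrogen again leaves the number within the scatter of the 4-cyanophenyl reference, with a 1.7-fold lower number from compound 1 to compound 3 (0.23 log units; within the scatter), and this time the entering 3-methylbenzyl carries no nitrile and no chlorine. The two benzyl-type compounds can also now be compared directly: a 1.3-fold lower number from compound 2 to compound 3 (0.12 log units; within the scatter), so exchanging 2-chlorophenyl for 3-methylphenyl on the saturated chain carbon bound to the amide-type nitrogen also gives no step beyond the scatter, and across these three compounds no exchange at this position separates one number from another. Nothing on hand explains why these numbers lie so close together.

The compounds shown leave open whether a group without an aromatic ring on the amide-type nitrogen, such as a longer alkyl chain, or an aromatic group carrying an amine or a carboxylic acid, would give a step beyond the scatter. All three share the rest of the core, so they also give no reading of any change made elsewhere in it, for instance in place of the 4-chlorophenyl group.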